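Dithiocarbamate Benzamides: From Piperidine to Pyridinylamine

The source may report more compounds than this note shows. Statements on the series, on what has been measured and on what is new or still open speak of the compounds shown alone.

The study examines a pair of dithiocarbamate-linked benzamides and one further analogue. Compound 1 `Nc1ccccc1NC(=O)c1ccc(CSC(=S)N2CCN(C3CCCCC3)CC2)cc1` was tested in a functional assay on A-375 cells (Homo sapiens) for antiproliferative activity, read by CCK-8 assay, with a stated time of 72 h, tested at 2 uM (a lower number here means a weaker effect, a higher number a stronger effect of the compound at the concentration tested), and compound 1 gives 31.7%. Compound 2 `CC1CCN(C(=S)SCc2ccc(C(=O)Nc3ccccc3N)cc2)CC1`, in this assay, gives 32.7%. The two values lie within the usual scatter of each other, so compound 2 and compound 1 cannot be told apart on these numbers; compound 2 simply carries the higher of the two figures recorded.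

Compound 3 `CN(C(=S)SCc1ccc(C(=O)Nc2ccccc2N)cc1)c1cccnc1` has not yet been measured. It differs from compound 2 by methyl(pyridin-3-yl)amino in place of 4-methylpiperidin-1-yl on a thiocarbonyl carbon. Among the compounds with values here, nothing measured so far speaks to a change of this kind at the thiocarbonyl carbon, since the two measured compounds differ in another part of the structure and show no step between them beyond the scatter. The step from compound 2 to compound 3 is therefore expected to be small and of no certain direction, estimated as a number 2.7 percentage points lower from compound 2 to compound 3 (within the scatter). On that basis compound 3 is estimated to give 30% in this assay, with a likely range from 15% to 50%.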

Compound 3, a percentage reported as inhibition, at one concentration (the size of the read-out at that concentration, not a potency): 26.5%
Compound 3: the middle estimate sits 3.5 percentage points above what was measured, within the range that was stated.
By their numbers in this assay, from the lowest: compounds 3, 1 and 2 (each within the scatter of the next).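

In this assay, within the data shown here, replacing 4-methylpiperidin-1-yl with methyl(pyridin-3-yl)amino on a thiocarbonyl carbon gives a number 6.2 percentage points lower from compound 2 to compound 3 (within the scatter) and provides the first readable step at this position. The numbers therefore do not separate a six-membered non-aromatic ring from a six-membered aromatic ring with one hetero atom, even though the entering group also brings a hydrogen-bond acceptor that the leaving group lacks. No available evidence bears on this result.

Because this single exchange alters the ring and its attachment together, the compounds shown leave open what a simple phenyl group in place of the pyridin-3-yl ring, or a hydrogen in place of the methyl on the amine nitrogen, would give. They also leave open whether a morpholin-4-yl group or an open-chain diethylamino group on the same thiocarbonyl carbon would produce a step beyond the scatter in this assay or would stay as close to compound 2 as compound 3 does.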